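The source may report more compounds than this note shows. Statements on the series, on what has been measured and on what is new or still open speak of the compounds shown alone.

In an ADME assay on NIH3T3 cells (Mus musculus) for cytotoxicity, read by MTT assay (a higher number here means a weaker inhibitor, a lower number a stronger inhibitor), the three measured compounds give these numbers:

Compound 1 `N#Cc1c(-c2ccccc2O)c(C#N)c(=O)n(/N=C/c2cn(-c3ccccc3)nc2-c2ccccc2)c1N`: 162 ug/mL
Compound 2 `N#Cc1c(-c2cccc(Cl)c2)c(C#N)c(=O)n(/N=C/c2cn(-c3ccccc3)nc2-c2ccccc2)c1N`: 52 ug/mL
Compound 3 `N#Cc1c(-c2ccc([N+](=O)[O-])cc2)c(C#N)c(=O)n(/N=C/c2cn(-c3ccccc3)nc2-c2ccccc2)c1N`: 84 ug/mL

Compound 3 holds the second highest of the three numbers. Its nearest neighbour is compound 2, with a 1.6-fold higher number from compound 2 to compound 3 (0.21 log units; within the scatter), and its furthest is compound 1, with a 1.9-fold lower number from compound 1 to compound 3 (0.29 log units; within the scatter); both of these gaps lie within the scatter. Compound 4 `N#Cc1c(-c2ccccc2Br)c(C#N)c(=O)n(/N=C/c2cn(-c3ccccc3)nc2-c2ccccc2)c1N` has not been measured. It differs from compound 3 in one place: 2-bromophenyl in place of 4-nitrophenyl on an aromatic carbon. For the measured compounds named here, the steps that bear on this change are the two replacements of the same phenyl substituent already seen, a 1.9-fold lower number from compound 1 to compound 3 (0.29 log units; within the scatter) and a 1.6-fold higher number from compound 2 to compound 3 (0.21 log units; within the scatter), both within the scatter, while only a 3.1-fold lower number from compound 1 to compound 2 (0.49 log units; beyond the scatter) reached beyond it and then only modestly. A step of no more than modest size in this assay is therefore expected from compound 3 to compound 4, in either direction or none at all. Compound 4 is estimated at 75 ug/mL, with a range from 35 ug/mL to 160 ug/mL, which would mean an expected 1.1-fold lower number from compound 3 to compound 4 (0.05 log units; within the scatter).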

Compound 4, half-maximal inhibitory concentration: 174 ug/mL
Compound 4: middle estimate off by 2.3-fold (0.37 log units), on the low side; measured number outside the range, above it.
By their numbers in this assay, from the lowest: compounds 2, 3, 1 and 4 (each within the scatter of the next, the first and the last beyond it).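

In this assay this position now gives a step beyond the scatter on leaving the 4-nitrophenyl group, a 2.1-fold higher number from compound 3 to compound 4 (0.32 log units; beyond the scatter), and the largest step shown here, a 3.3-fold higher number from compound 2 to compound 4 (0.52 log units; beyond the scatter). Bromo in place of hydroxy on the same phenyl ring makes no difference that exceeds the scatter, a 1.1-fold higher number from compound 1 to compound 4 (0.03 log units; within the scatter), so the 2-bromophenyl and 2-hydroxyphenyl groups read alike. Nothing shown accounts for these differences.

As far as these compounds go, it remains open whether the ring's substitution site or the substituent itself drives these numbers, since no single group appears at two sites. From the compounds shown here alone, how an unsubstituted phenyl ring or a methoxy or amino group would read is also open.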